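Methyl gives way to methoxy on compound 2

The source may report more compounds than this note shows. Statements on the series, on what has been measured and on what is new or still open speak of the compounds shown alone.

Compound 1, `O=C1c2ccccc2C(=O)N1CCCCN1CCC(n2c(O)nc3ccccc32)CC1`, in an in vitro assay on HEK293 cells with Alpha-1D adrenergic receptor (Homo sapiens) as the target; on this read-out lower numbers stand for stronger inhibition and higher numbers for weaker inhibition: 16 nM
Compound 2, `Cc1ccc2c(c1)oc(=O)n2C1CCN(CCCCN2C(=O)c3ccccc3S2(=O)=O)CC1`, in this assay: 644 nM
Compound 3, `Cc1cc(C)c2oc(=O)n(C3CCN(CCCCN4C(=O)c5ccccc5S4(=O)=O)CC3)c2c1`, in this assay: 224 nM

Among these three, compound 2 gives the highest number in this assay. The nearest of the others is compound 3, whose lower number lies beyond the usual scatter of repeated measurements; the furthest is compound 1, whose much lower number also lies well beyond it. Compound 2 is therefore the weakest inhibitor of the three on this read-out.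

The next compound, compound 4, is `COc1ccc2c(c1)oc(=O)n2C1CCN(CCCCN2C(=O)c3ccccc3S2(=O)=O)CC1`. It differs from compound 2 in a single place: methoxy in place of methyl on an aromatic carbon. Within the data shown here, no pair of measured compounds shows this same exchange, so there is no measured step to lean on, only the two structures and the value of compound 2.

On that basis a modest move is expected from compound 2 to compound 4, likely no larger than the scatter itself and, if anything, toward a lower number; the expected step is a 1.3-fold lower number from compound 2 to compound 4 (0.11 log units; within the scatter). The estimate for compound 4 in this assay is 500 nM, within a range from 180 nM to 1400 nM.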

Compound 4, inhibition constant: 2750 nM
Beside the measured number, compound 4's estimate is 5.5-fold (0.74 log units) below it; the whole stated range lies below it.
By their numbers in this assay, from the lowest: compound 1; then compound 3; then compound 2; then compound 4.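

In this assay, the aromatic carbon that is meta to a fused ring and para to a fused ring proves sensitive to the group it carries: methoxy in place of methyl gives a 4.3-fold higher number from compound 2 to compound 4 (0.63 log units; beyond the scatter), a clear move toward weaker inhibition. The exchange is small by count, adding only an oxygen and a hydrogen-bond acceptor, yet compound 4, at 2750 nM, now has the highest number of the four compounds. No measurement at hand explains why this exchange raises the number.

The compounds shown leave open whether the step follows from the oxygen of methoxy or from the extra heavy atom alone, a question that an ethyl group on the same carbon could help to separate, with a hydroxyl group or a fluorine atom there adding further comparisons. They also leave open whether the same exchange would carry the same step on the core of compound 1 or on the dimethyl-substituted core of compound 3.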